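The source may report more compounds than this note shows. Statements on the series, on what has been measured and on what is new or still open speak of the compounds shown alone.

Working notes on the series. Two compounds have numbers in a functional assay on AGS cells (Homo sapiens) for antiproliferative activity, read by CCK-8 assay, with a stated time of 72 h; on this read-out lower numbers stand for stronger inhibition and higher numbers for weaker inhibition. Compound 1 `CC1(O)CCN(c2ccn3c(-c4ccc(NC(=O)c5ccc([N+](=O)[O-])o5)cc4)cnc3c2)CC1` gives 1530 nM in this assay. Compound 2 `COc1ccn2c(-c3ccc(NC(=O)c4ccc([N+](=O)[O-])o4)cc3)cnc2c1` gives 720 nM in this assay. The only one-place step so far runs from compound 1 to compound 2 and is a 2.1-fold lower number from compound 1 to compound 2 (0.33 log units; beyond the scatter); on the two numbers shown, compound 2 stands lowest, with compound 1 as its nearest neighbour.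

Compound 3 `COc1ccn2c(-c3ccc(NC(=O)c4ccc([N+](=O)[O-])o4)cc3OC)cnc2c1` is not yet measured. It differs from compound 2 by methoxy in place of hydrogen on an aromatic carbon. For the measured compounds named here, no measured step bears on this change: the step from compound 1 to compound 2 concerns a different position and a different kind of group, so it offers no guide to the size or direction here. With nothing to go on, no change beyond the scatter is expected, and the step from compound 2 to compound 3 is estimated at a 1.1-fold higher number from compound 2 to compound 3 (0.05 log units; within the scatter). Compound 3 is therefore expected to give about 800 nM in this assay, within a range of 300 nM to 2500 nM.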

Compound 3, half-maximal inhibitory concentration: > 20000 nM
Compound 3: no number, only a limit; the forecaster's own chance of this, stated with the estimate: 5%; at least 25-fold (1.39 log units) between middle value and limit.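

For the compounds shown here, this is the first measured change on the six-membered aromatic ring of carbon only, at the carbon ortho to a large group and meta to a large group, and it shows that this place does not tolerate every small addition: in this assay, methoxy in place of hydrogen gives an at least 27-fold higher number from compound 2 to compound 3 (1.44 log units; beyond the scatter). That step is far larger than the only earlier one, a 2.1-fold lower number from compound 1 to compound 2 (0.33 log units; beyond the scatter), which lies at a different place in the core. Compound 3 has a limit of the assay and not a number, so the step has a lower bound only: the limit of > 20000 nM in this assay, at which 1 of the 3 values shown sits.

Whether this result belongs to methoxy itself or to any group at this carbon stays open, as only hydrogen and methoxy are shown there. A fluorine atom, a methyl or a hydroxyl at the same carbon would separate these two readings.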